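The source may report more compounds than this note shows. Statements on the series, on what has been measured and on what is new or still open speak of the compounds shown alone.

Measured compounds:
- compound 1, `COc1ccc(/C=C/C=C/C(=O)c2ccc(F)cc2)cc1`: "not determined" (no result reported)
- compound 2, `COc1ccc(/C=C/C=C/C(=O)c2cc(C)oc2C)cc1`: > 100000 nM

The account follows one change made to compound 1. In an ADME assay on RAW264.7 cells (Mus musculus) for cytotoxicity, read by MTT assay (a lower number here means a stronger inhibitor, a higher number a weaker inhibitor), compound 1 gives "not determined" (no result reported), so no figure of its own is available for it. Going by the values given here, only one value is known in this assay, and it belongs to compound 2. For compound 2 this assay reports only a limit, > 100000 nM, which is a boundary of the measurement and not a number. Compound 1 therefore stands without a place of its own on the scale, and the only landmark near it is the limit of > 100000 nM in this assay, at which 1 of the 2 values shown sits.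

Compound 3, `O=C(/C=C/C=C/c1ccc(O)cc1)c1ccc(F)cc1`, is reached from compound 1 by one change: hydrogen in place of methyl on an oxygen on an aromatic ring. Among the compounds with values here, no measured pair in this assay shows the size of such a step, so the account can only state an expectation. Within the data shown here, with a single limit as the only evidence, no step beyond the scatter in this assay is expected in either direction. Compound 3 is therefore estimated to give about 60000 nM in this assay, with a range from 15000 nM to 200000 nM.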

Compound 3, half-maximal inhibitory concentration: 45500 nM
Compound 3: middle estimate off by 1.3-fold (0.12 log units), on the high side; the measured number falls inside the stated range.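

No step can be read from the result for compound 3: compound 1, one change away, has no number of its own in this assay, and compound 2 differs from compound 3 in more than one place. Compound 2 offers only a limit: the limit of > 100000 nM in this assay, at which 1 of the 3 values shown sits.

The compounds shown leave open how large a step the change from methoxy to hydroxy makes in this assay.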